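The source may report more compounds than this note shows. Statements on the series, on what has been measured and on what is new or still open speak of the compounds shown alone.

For the measured compounds named here, in a functional assay on NCI/ADR-RES cells (Homo sapiens) for inhibition, read by sulforhodamine B assay, with a stated time of 48 h, tested at 10 uM (a lower number here means less inhibition, a higher number more inhibition at the concentration tested (going by the name of the read-out)), compound 2 `COc1ccc(-c2cn3ccnc3c(-c3ccc4ncn(C5CCCCC5)c4c3)n2)cc1` gives 87.2%, the highest of the two numbers so far; its nearest neighbour, compound 1 `Brc1cn2ccnc2c(-c2ccc3ncn(C4CCCCC4)c3c2)n1`, gives 8.82%. Going by the values given here, the single measured step, a number 78.4 percentage points higher from compound 1 to compound 2 (beyond the scatter), shows a large rise when an aryl group replaces bromo on the aromatic carbon. Compound 3 `c1ccc2c(-c3cn4ccnc4c(-c4ccc5ncn(C6CCCCC6)c5c4)n3)cccc2c1` differs from compound 2 by naphthalen-1-yl in place of 4-methoxyphenyl on an aromatic carbon. Since both compounds carry an aryl group there, that step bears on the change only loosely, and the expected step of a number 15.2 percentage points lower from compound 2 to compound 3 (beyond the scatter) is small, downward if anything, within the scatter. Compound 3 is estimated at 72%, between 35% and 95%.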

Compound 3, a percentage reported as inhibition, at one concentration (the size of the read-out at that concentration, not a potency): 4.43%
Estimate against measurement, compound 3: 67.6 percentage points above, outside the stated range (below it).
By their numbers in this assay, from the lowest: compounds 3 and 1 (each within the scatter of the next); then compound 2.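

With a number 82.8 percentage points lower from compound 2 to compound 3 (beyond the scatter) and a number 4.4 percentage points lower from compound 1 to compound 3 (within the scatter) in this assay at this aromatic carbon, an aryl group as such does not carry the high reading. Naphthalen-1-yl leaves compound 3 level with the bromo compound 1, and among these three groups only 4-methoxyphenyl stands apart. Nothing measured here accounts for this difference. As far as these compounds go, it remains open whether the methoxy group itself matters, or whether plain phenyl, 4-hydroxyphenyl or an amine at the same carbon would keep the reading of compound 2. From the compounds shown here alone, the effect of other groups in place of the cyclohexyl ring also remains open.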